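A Methyl Added to the Tetrazole Analogue

The source may report more compounds than this note shows. Statements on the series, on what has been measured and on what is new or still open speak of the compounds shown alone.

Measured compounds:
Compound 1, `Cc1cccc2cc(C(=O)O)cnc12`: in a functional assay on the whole organism (strain Sprague-Dawley) for inhibition, with Rattus norvegicus as the target (a higher number here means that more compound is needed for the effect, a lower number that less compound is needed), compound 1 gives > 50 mg/kg, which is a limit of the assay and not a number.
Compound 2, `Cc1ccc2cc(C(=O)O)cnc2c1C`: in this assay compound 2 gives 25 mg/kg.
Compound 3, `c1ccc2ncc(-c3nn[nH]n3)cc2c1`: in this assay compound 3 gives 10 mg/kg.

Compound 1 sits at the limit of > 50 mg/kg in this assay, at which 1 of the 3 values shown sits. From compound 1 to compound 2 the change is methyl in place of hydrogen on an aromatic carbon, and it brought an at least 2.0-fold lower number from compound 1 to compound 2 (0.30 log units; that floor lies within the scatter). Compound 3 stands lowest of the two numbers in this assay, and its gap to compound 2 lies beyond the scatter. How the core of compound 3 differs from the core of compound 1 is not broken down here.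

Compound 4, `Cc1cccc2cc(-c3nn[nH]n3)cnc12`, has not yet been measured in this assay. It differs from compound 3 by methyl in place of hydrogen on an aromatic carbon. Within the data shown here, this is the same kind of change as the one from compound 1 to compound 2, but not the same: there the methyl enters ortho to a methyl group, meta to a fused ring and para to a fused ring, whereas here it enters ortho to a fused ring and meta to a fused ring. That measured step also sits at a different place from the one proposed here. Because an at least 2.0-fold lower number from compound 1 to compound 2 (0.30 log units; that floor lies within the scatter) reached only the floor of the scatter, a methyl on the core of compound 3 is expected to leave the number close to where compound 3 stands. Compound 4 is therefore estimated at 10 mg/kg in this assay, between 4 mg/kg and 40 mg/kg, which means an expected step of no change at the digits printed from compound 3 to compound 4 (within the scatter).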

Compound 4, minimum effective dose: < 25 mg/kg
Compound 4: a limit, no number; the forecaster's own chance of this, stated with the estimate: 15%; the middle value is on the limit's open side.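

In this assay compound 4 gives < 25 mg/kg, which is a limit of the assay and not a number: the limit of < 25 mg/kg in this assay, at which 1 of the 4 values shown sits. The step from compound 3 to compound 4 cannot be read, so the result does not show whether methyl in place of hydrogen on an aromatic carbon, which gave an at least 2.0-fold lower number from compound 1 to compound 2 (0.30 log units; that floor lies within the scatter) at a different place on the carboxy core, carries over to the core of compound 3 with a similar size, a larger one or none at all. Among these compounds, the one step that can be read is a change of another kind, 2H-tetrazol-5-yl in place of carboxy on an aromatic carbon, with an at least 2.0-fold lower number from compound 1 to compound 4 (0.30 log units; that floor lies within the scatter), and it is only a floor set by a limit: the limit of > 50 mg/kg in this assay, at which 1 of the 4 values shown sits.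

The compounds shown leave open where compound 4 stands on the scale of this assay, and so whether the methyl ortho to a fused ring and meta to a fused ring moves the number at all on the core of compound 3. They also leave open what an ethyl group, a methoxy group or an amine at that same place would do on either core.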